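A thiazolyl amide in place of the pyridyl

This account rests on a few compounds, and the source may have more. Where it says the series, first, only, none or still open, it means among the compounds named here.

The compounds with numbers so far:
compound 1, `COc1ccc(C(=O)Nc2c(F)cccc2F)cc1OC1CCCC1`, 70 nM
compound 2, `COc1ccc(C(=O)Nc2c(F)cccc2F)cc1OC1CCCCC1`, 400 nM
compound 3, `COc1ccc(C(=O)Nc2ccncc2)cc1OC1CCCC1`, 800 nM

All three share one core and are set apart by two positions. In an assay on isolated protein for inhibition of phosphodiesterase 4A (Sus scrofa) (a lower number here means a stronger inhibitor, a higher number a weaker inhibitor), compound 3 gives 800 nM, the highest of the three numbers. Against compound 2, with 400 nM, the two values sit within the scatter of each other. Against compound 1 the gap is real: an 11-fold higher number from compound 1 to compound 3 (1.06 log units; beyond the scatter). The other measured step, a 5.7-fold higher number from compound 1 to compound 2 (0.76 log units; beyond the scatter), concerns the cycloalkyl ether and does not touch the position changed here.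

Compound 4, `COc1ccc(C(=O)Nc2c(C)nsc2C#N)cc1OC1CCCC1`, has not yet been measured. It differs from compound 3 in this way: 5-cyano-3-methyl-1,2-thiazol-4-yl in place of pyridin-4-yl on an amide-type nitrogen. Within the data shown here, the only step that bears on this position is the one from compound 1 to compound 3, and it was large, which shows that the group on the amide-type nitrogen moves this assay strongly. Among the measured compounds shown here, no measured step tells which direction a five-membered ring with a nitrile and a methyl will take. The estimate for compound 4 is therefore a modest step downward, a 4.0-fold lower number from compound 3 to compound 4 (0.60 log units; beyond the scatter), with a wide range. Compound 4 is expected at 200 nM, between 40 nM and 1000 nM.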

Compound 4, half-maximal inhibitory concentration: 200 nM
Beside the measured number, compound 4's estimate shows no gap at the digits printed, within the range that was stated.
By their numbers in this assay, from the lowest: compound 1; then compounds 4, 2 and 3 (each within the scatter of the next, the first and the last beyond it).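

In this assay, the group on the amide-type nitrogen proved able to move the number down as well as up: the 5-cyano-3-methyl-1,2-thiazol-4-yl group in place of pyridin-4-yl gives a 4.0-fold lower number from compound 3 to compound 4 (0.60 log units; beyond the scatter) and so wins back part of what the pyridyl had lost. It does not reach the 2,6-difluorophenyl group, with a 2.9-fold higher number from compound 1 to compound 4 (0.46 log units; beyond the scatter) remaining, so the three groups tested on the cyclopentyl ether now form an order in which each gap lies beyond the scatter, with 2,6-difluorophenyl lowest, the thiazolyl group in the middle and pyridin-4-yl highest. Nothing at hand says what about the thiazolyl group accounts for these steps.

Still open, from the compounds shown here alone, is how the gain divides between the nitrile and the methyl, and whether an amine or a carboxylic acid in the place of the nitrile would keep it. Also open, going by these compounds, is whether the thiazolyl group would hold its standing on the cyclohexyl ether, where compound 2, with its 2,6-difluorophenyl group, gives 400 nM in this assay.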